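The source may hold more compounds than are shown below. What is called first, only, known or untested is meant among the compounds shown, and "the series" means these compounds.

Working notes on the series.

Compound 1 `CCc1ccc(NC(=O)Cn2cc(COc3ccc4c(c3)CCC4)nn2)cc1` is the reference point for the step considered here. In an ADME assay on HEK293 cells (Homo sapiens) for inhibition, read by MTT assay, with a stated time of 48 h, tested at 25 uM (a higher number here means more inhibition at the concentration tested (going by the name of the read-out), a lower number less inhibition), the result for compound 1 is recorded as "not determined" (no result reported), so compound 1 stands at no single number on this read-out. Within the data shown here, the only measured member is compound 2 `Brc1ccccc1-n1cc(COc2ccc3c(c2)CCC3)nn1`, which shares the ether-linked portion of compound 1 but carries a different substituent on the triazole nitrogen; in this assay compound 2 gives 16.5%, a low level of inhibition at the single concentration tested.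

Compound 3 `COc1ccccc1NC(=O)Cn1cc(COc2ccc3c(c2)CCC3)nn1` differs from compound 1 in one place: 2-methoxyphenyl in place of 4-ethylphenyl on an amide-type nitrogen. Among the measured compounds shown here, no measured pair reports this kind of change, so the size of the step in this assay from compound 1 to compound 3 cannot be read from the data; the expectation is a step of no size beyond the usual scatter, in either direction. For the measured compounds named here, with compound 1 lacking a value, the only anchor is compound 2, whose value in this assay of 16.5% sits in the low range, and compound 3 is expected to land near that range as well.

Compound 3 is estimated at 15% in this assay, with a range from 0% to 35%.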

Compound 3, a percentage reported as inhibition, at one concentration (the size of the read-out at that concentration, not a potency): 23.4%
Beside the measured number, compound 3's estimate is 8.4 percentage points below it, and the stated range covers the measured number.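

Among these compounds, compound 1 has no single number in this assay, so no step to compound 3 can be read from this result. The compounds shown leave open how the change from 4-ethylphenyl to 2-methoxyphenyl on the amide-type nitrogen affects inhibition in this assay. No available evidence bears on this result.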